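Amide Variation on a Shared Core in the Writhing Test

The compounds below may be only part of what the source reports. "The series", "measured", "known", "first", "only" and "open" are said of these compounds alone.

In a functional assay on the whole organism (strain Swiss albino) for inhibition, with Mus musculus as the target, in the writhing test, with stated times of 60 min and 15 min, at a dose of 100 mg/kg by the oral route (a higher number here means more inhibition at the dose given (going by the name of the read-out), a lower number less inhibition), three compounds have been measured so far:
compound 1, `COc1cc2c(cc1OC)C(CC(=O)N(C)C)CC2`, gives 22.6%;
compound 2, `CCCCNC(=O)CC1CCc2cc(OC)c(OC)cc21`, gives 39.4%;
compound 3, `COc1cc2c(cc1OC)C(CC(=O)N1CCCCC1)CC2`, gives 44.7%.

Compound 1 stands lowest of the three, and both other compounds lie beyond the scatter above it. The two steps that start from compound 1 each replace dimethylamino on the carbonyl carbon by a larger group: a number 16.8 percentage points higher from compound 1 to compound 2 (beyond the scatter) and a number 22.1 percentage points higher from compound 1 to compound 3 (beyond the scatter). Between the two larger groups the difference is small, a number 5.3 percentage points higher from compound 2 to compound 3 (within the scatter), so the two values of compound 2 and compound 3 cannot be ordered.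

Compound 4, `COc1cc2c(cc1OC)C(CC(=O)N1CCOCC1)CC2`, differs from compound 1 in one place: morpholin-4-yl in place of dimethylamino on a carbonyl carbon. The entering group is again larger than dimethylamino and, like piperidin-1-yl, forms a six-membered non-aromatic ring. The two measured steps away from dimethylamino both bear on this change and both were modest rises beyond the scatter. A rise of similar size is therefore expected for compound 4 in this assay, a number 15.4 percentage points higher from compound 1 to compound 4 (beyond the scatter). The estimate for compound 4 is 38%, with a range from 25% to 52%.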

Compound 4, a percentage reported as inhibition, in the whole organism at one dose (the size of the read-out at that dose, not a potency): 23.6%
The estimate for compound 4 lay 14.4 percentage points above the measured number; measured number outside the range, below it.
By their numbers in this assay, from the lowest: compounds 1 and 4 (each within the scatter of the next); then compounds 2 and 3 (each within the scatter of the next).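

In this assay a larger group holding a six-membered non-aromatic ring is not enough for a rise on this carbonyl carbon: morpholin-4-yl in place of dimethylamino gives a number 1 percentage points higher from compound 1 to compound 4 (within the scatter) and so no readable change. The two rings differ in one ring atom, an oxygen in morpholin-4-yl where piperidin-1-yl has a carbon, yet that swap gives a number 21.1 percentage points lower from compound 3 to compound 4 (beyond the scatter) and morpholin-4-yl in place of butylamino gives a number 15.8 percentage points lower from compound 2 to compound 4 (beyond the scatter) as well. No measurement at hand explains this loss.

Still open, going by these compounds, is whether a different ring atom at that spot, as in thiomorpholin-4-yl or 4-methylpiperazin-1-yl, would give a number like that of compound 3 or like those of compound 1 and compound 4. On these data alone, a five-membered ring such as pyrrolidin-1-yl also remains open.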